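A few compounds are considered here, and "the series" means these few. Any claim that something is new, unique, unknown or untested is made for them only; others in the source may bear on it.

Measured in an ADME assay on Vero cells (Chlorocebus sabaeus) for cytotoxicity, read by MTT assay; on this read-out lower numbers stand for higher toxicity in this test and higher numbers for lower toxicity in this test:
Compound 1 `Cn1nc(C(F)(F)F)cc1C(=O)Nc1ccc(S(=O)(=O)OC2CCCCC2)cc1`: > 300000 nM
Compound 2 `Cn1nc(C(F)(F)F)cc1C(=O)Nc1ccc(S(=O)(=O)N2CCC(NC(=O)OC(C)(C)C)CC2)cc1`: > 300000 nM

Neither entry is a number, and the evidence so far is the limit of > 300000 nM in this assay, at which 2 of the 2 values shown sit. Compound 2 therefore has no exact place on the scale: it gives > 300000 nM, which is a limit of the assay.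

Compound 3 `Cn1nc(C(F)(F)F)cc1C(=O)Nc1ccc(S(=O)(=O)N2CCC(O)CC2)cc1` differs from compound 2 at one place. It carries hydroxy in place of (tert-butoxycarbonyl)amino on a saturated ring carbon of a six-membered non-aromatic ring with 1 nitrogen, three ring bonds from the ring nitrogen. The count of that change is hydroxy in place of (tert-butoxycarbonyl)amino on a saturated ring carbon.

Among the measured compounds shown here, no step between measured compounds exists yet, so nothing measured shows the size of such a change. The change expected in this assay is none beyond the scatter, and the likeliest result is that the assay again reports only a limit. This expectation rests on compound 2, which gives > 300000 nM. The estimated step is a number no higher from compound 2 to compound 3 (the limit leaves the size open). For compound 3 the expected value is 300000 nM, with an estimated range from 100000 nM to 500000 nM.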

Compound 3, half-maximal cytotoxic concentration: 274000 nM
Beside the measured number, compound 3's estimate is 1.1-fold (0.04 log units) above it; measured number inside the range.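

In this assay, among the compounds shown here, compound 3 gives 274000 nM as the first exact number in this set, and it still sits high on the scale, where higher numbers stand for lower toxicity in this test. Hydroxy in place of (tert-butoxycarbonyl)amino on a saturated ring carbon gives an at least 1.0-fold lower number from compound 2 to compound 3 (0.03 log units; that floor lies within the scatter) and 4-hydroxypiperidin-1-yl in place of cyclohexyloxy on a sulfonyl sulfur gives an at least 1.0-fold lower number from compound 1 to compound 3 (0.03 log units; that floor lies within the scatter) and so neither step shows a real change. Both steps start from a limit of the assay, so their true size stays open, and the start of each is no more than this: the limit of > 300000 nM in this assay, at which 2 of the 3 values shown sit.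

On these data alone, how a free amine or a carboxylic acid on that same ring carbon would read remains open, as does a longer chain ending in hydroxy. How far the true numbers of compound 1 and compound 2 lie past their limit also cannot be told from these results, so a larger drop from either one to compound 3 cannot be ruled out.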